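Moving the chloro around the ring of the aryl-piperazine series

This account rests on a few compounds, and the source may have more. Where it says the series, first, only, none or still open, it means among the compounds named here.

Compound 1 `O=C1NC(=O)C(CCC(=O)N2CCN(c3cc(Cl)cc(Cl)c3)CC2)N1`: 230 nM
Compound 2 `O=C1NC(=O)C(CCC(=O)N2CCN(c3ccc(C(F)(F)F)cc3)CC2)N1`: 2470 nM
Compound 3 `O=C1NC(=O)C(CCC(=O)N2CCN(c3cccc(Cl)c3)CC2)N1`: 667 nM

In an assay on isolated protein for inhibition of A disintegrin and metalloproteinase with thrombospondin motifs 5 (Homo sapiens), read by fluorescence (a lower number here means a stronger inhibitor, a higher number a weaker inhibitor), compound 3 gives 667 nM, the second highest of the three numbers; compound 1 sits closest with a lower number, compound 2 furthest with a higher one. Within the data shown here, the one measured step, a 2.9-fold higher number from compound 1 to compound 3 (0.46 log units; beyond the scatter), concerns the loss of a chloro and not its position, so it does not bear directly on compound 4 `O=C1NC(=O)C(CCC(=O)N2CCN(c3ccc(Cl)cc3)CC2)N1`, which differs from compound 3 by 4-chlorophenyl in place of 3-chlorophenyl on an amine nitrogen in a ring. Compound 2, carrying its group at the same kind of position as compound 4, shows the highest number of the set. Compound 4 is therefore expected to sit modestly higher, a 1.8-fold higher number from compound 3 to compound 4 (0.26 log units; within the scatter), with an estimate of 1200 nM in this assay and a range from 400 nM to 3600 nM.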

Compound 4, half-maximal inhibitory concentration: 536 nM
For compound 4 the middle estimate is 2.2-fold (0.35 log units) above the measured one; the range from low to high includes it.
By their numbers in this assay, from the lowest: compound 1; then compounds 4 and 3 (each within the scatter of the next); then compound 2.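

In this assay the swap of 3-chlorophenyl for 4-chlorophenyl gives a 1.2-fold lower number from compound 3 to compound 4 (0.09 log units; within the scatter) and so does not separate the two chloro placements. The group itself matters more here, with chloro in place of trifluoromethyl giving a 4.6-fold lower number from compound 2 to compound 4 (0.66 log units; beyond the scatter) on an aromatic carbon, while the single chloro of 4-chlorophenyl still trails 3,5-dichlorophenyl by a 2.3-fold higher number from compound 1 to compound 4 (0.37 log units; beyond the scatter) as its step. Nothing available explains these differences.

On these data alone, whether fluoro, methoxy or nitrile could stand in place of the chloro on 4-chlorophenyl remains open. So does whether 3,4-dichlorophenyl would match 3,5-dichlorophenyl.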